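Replacing the acrylamide of compound 2 with a saturated ester

A few compounds are considered here, and "the series" means these few. Any claim that something is new, unique, unknown or untested is made for them only; others in the source may bear on it.

Three compounds share a core and differ only in the amide portion of the side chain. Compound 1 `COC1CN(C(=O)/C=C/c2ccncc2-c2ccc3ccccc3c2)C1` gives 100% in an assay on a protein complex for inhibition of CDK8/Cyclin C (Homo sapiens), with a stated time of 1 h, tested at 10 uM; a higher number here means more inhibition at the concentration tested (going by the name of the read-out), a lower number less inhibition. Compound 2 `O=C(/C=C/c1ccncc1-c1ccc2ccccc2c1)NC1CC1` gives 102% in this assay, and compound 3 `CN1CCN(C(=O)/C=C/c2ccncc2-c2ccc3ccccc3c2)CC1` gives 101%. The steps among them are small: a number 2 percentage points higher from compound 1 to compound 2 (within the scatter), a number 1 percentage points higher from compound 1 to compound 3 (within the scatter) and a number 1 percentage points lower from compound 2 to compound 3 (within the scatter). Compound 2 holds the highest number of the three, but since every step to it lies within the scatter, no ordering among the three can be drawn.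

Compound 4 `COC(=O)CCc1ccncc1-c1ccc2ccccc2c1` is the unmeasured compound. Its change from compound 2 is 2-(methoxycarbonyl)ethyl in place of 2-(cyclopropylcarbamoyl)ethenyl on an aromatic carbon. Going by the values given here, none of the measured steps bears directly on this change: all three vary only the amine attached to the carbonyl, while here the carbonyl amide and the double bond leave together and an ester on a saturated chain enters. The measured steps therefore give no guide to the size or direction of the step in this assay, and the estimate must be wide.

The expected value for compound 4 is 60%, with a range from 15% to 100%; the expected step is a number 42 percentage points lower from compound 2 to compound 4 (beyond the scatter).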

Compound 4, a percentage reported as inhibition, at one concentration (the size of the read-out at that concentration, not a potency): 98%
Compound 4: the middle estimate sits 38 percentage points below what was measured; the measured number falls inside the stated range.
By their numbers in this assay, from the lowest: compounds 4, 1, 3 and 2 (each within the scatter of the next).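

In this assay, the step is a number 4 percentage points lower from compound 2 to compound 4 (within the scatter), so the 2-(methoxycarbonyl)ethyl and 2-(cyclopropylcarbamoyl)ethenyl compounds cannot be told apart at the one concentration tested. The earlier compounds shown here varied only the amine on the carbonyl, whereas this change, on the aromatic carbon opposite the ring nitrogen, removes the amide hydrogen, the three-membered ring and the chain double bond together, and the read-out still gives no step beyond the scatter. This read-out is not a potency, and the result says nothing about how potency compares between the two compounds. No measurement shown explains this result.

The compounds shown do not separate the loss of the chain double bond from the exchange of the amide for an ester, as a saturated cyclopropyl amide or an unsaturated methyl ester at this position would do. They also leave open what number a carboxylic acid, a primary amine or a longer chain ending in the same methyl ester would give at this position in this assay.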